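Cyclopropyl in place of 4-fluorophenyl: notes on the series

The source may hold more compounds than are shown below. What is called first, only, known or untested is meant among the compounds shown, and "the series" means these compounds.

Measured so far in a functional assay on HepG2 cells (Homo sapiens) for antiproliferative activity, read by MTT assay, with a stated time of 72 h; a higher number here means a weaker inhibitor, a lower number a stronger inhibitor (values as read):
- compound 1 `COc1cccc(N2C(=O)COc3ccc(-c4cnc(OC)c(NS(=O)(=O)c5ccc(F)cc5)c4)cc32)c1` gives > 40000 nM (a limit, not a number)
- compound 2 `COc1ncc(-c2ccc3c(c2)N(c2ccc(F)cc2)C(=O)CO3)cc1NS(=O)(=O)c1ccc(F)cc1` gives 36400 nM (a number)

Among the measured compounds shown here, compound 2 carries the only true number so far. For the measured compounds named here, the other reading is the one for compound 1, and it is a limit (see (the limit of > 40000 nM in this assay, at which 1 of the 2 values shown sits)).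

The next compound is compound 3 `COc1ncc(-c2ccc3c(c2)N(C2CC2)C(=O)CO3)cc1NS(=O)(=O)c1ccc(F)cc1` with cyclopropyl in place of 4-fluorophenyl on an amide-type nitrogen in a ring (counted: cyclopropyl in place of 4-fluorophenyl on an amide-type nitrogen in a ring). The rest of the structure stays as in compound 2.

Going by the values given here, one measured step bears on this place. It shows an at least 1.0-fold lower number from compound 1 to compound 2 (0.04 log units; that floor lies within the scatter) on putting 4-fluorophenyl where 3-methoxyphenyl stood. Among the compounds with values here, that step exchanges one phenyl group for another, and no measured step removes the phenyl group altogether, so the guide is thin and the range must stay wide.

The estimated change is a 1.5-fold lower number from compound 2 to compound 3 (0.16 log units; within the scatter) in this assay and no step beyond the scatter is expected. A further reading at the limit is also expected to be possible. Compound 3 is estimated at 25000 nM (expected range 7000 nM to 70000 nM).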

Compound 3, half-maximal inhibitory concentration: 14400 nM
Beside the measured number, compound 3's estimate is 1.7-fold (0.24 log units) above it; the measured number falls inside the stated range.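

In this assay, among the compounds shown here, the phenyl-type group on the amide-type nitrogen in a ring is not needed for the reading: putting cyclopropyl in place of 4-fluorophenyl gives a 2.5-fold lower number from compound 2 to compound 3 (0.40 log units; beyond the scatter), the first step at this position that lies beyond the scatter, and it comes with a smaller group, a three-membered non-aromatic ring of carbon only. Set against the 3-methoxyphenyl group, cyclopropyl gives an at least 2.7-fold lower number from compound 1 to compound 3 (0.44 log units; beyond the scatter), so both phenyl-bearing compounds now read on the weaker side of compound 3, although that second step is only a floor. Compound 1 stands at a limit, not a number: the limit of > 40000 nM in this assay, at which 1 of the 3 values shown sits.

As far as these compounds go, what remains open is whether the step belongs to cyclopropyl itself or to small carbon groups on this nitrogen in general, since a methyl group, a longer chain such as n-butyl or a chain ending in an amine would each separate these readings. From the compounds shown here alone, compound 3 still gives 14400 nM, so it is also open whether any change at this position alone can move the series far from this range.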